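From isopentyl to (5-fluoropyridin-2-yl)methyl: compound 2 to compound 3

The source may report more compounds than this note shows. Statements on the series, on what has been measured and on what is new or still open speak of the compounds shown alone.

In an ADME assay on 2209-23 cells (Homo sapiens) for cytotoxicity, read by WST assay and thymidine incorporation (on this read-out higher numbers stand for lower toxicity in this test and lower numbers for higher toxicity in this test), compound 1 `CC(C)(C)CCN1C(=O)C(C2=CS(=O)(=O)c3cc(NS(C)(=O)=O)ccc3N2)=C(O)[C@@H]1C(C)(C)C` gives > 50000 nM, which is a limit of the assay and not a number. Compound 2 `CC(C)CCN1C(=O)C(C2=CS(=O)(=O)c3cc(NS(C)(=O)=O)ccc3N2)=C(O)[C@@H]1C(C)(C)C` gives > 50000 nM, again a limit, so its true position on the scale is not known. Going by the values given here, the whole series so far is summed up by the limit of > 50000 nM in this assay, at which 2 of the 2 values shown sit.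

Compound 3 `CC(C)(C)[C@H]1C(O)=C(C2=CS(=O)(=O)c3cc(NS(C)(=O)=O)ccc3N2)C(=O)N1Cc1ccc(F)cn1` differs from compound 2 by 5-fluoropyridin-2-yl in place of isobutyl on a saturated chain carbon bound to an amide-type nitrogen in a ring: 5-fluoropyridin-2-yl in place of isobutyl, or, cut one bond further out, isopentyl to (5-fluoropyridin-2-yl)methyl, on a saturated chain carbon bound to an amide-type nitrogen in a ring.

Among the compounds with values here, only one measured step bears on this change, a step that the two limits leave unreadable from compound 1 to compound 2. It alters the same chain, but it has no readable size to carry over, and neither measured compound holds an aromatic ring at this place. Within the data shown here, with only that evidence, no step beyond the scatter is expected in this assay, and no direction can be given. The expected change is a number no higher from compound 2 to compound 3 (the limit leaves the size open), and a further report as a limit is likely. For compound 3 the estimated value is 50000 nM, with an expected range of 25000 nM to 100000 nM.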

Compound 3, half-maximal cytotoxic concentration: > 50000 nM
Compound 3: only a limit was reported; the forecaster's own chance of this, stated with the estimate: 85%; the middle value lies on the limit itself.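

No step can be read between compound 1, compound 2 and compound 3, since each result is a limit and not a number: the limit of > 50000 nM in this assay, at which 3 of the 3 values shown sit.

The compounds shown leave open where their true values lie in this assay, and whether (5-fluoropyridin-2-yl)methyl in place of isopentyl changes the read-out at all.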